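Swapping dimethylamino for methyl on a sulfonyl sulfur

The source may report more compounds than this note shows. Statements on the series, on what has been measured and on what is new or still open speak of the compounds shown alone.

Of the compounds shown here, three built on a shared core have been measured so far in an in vivo ADME assay on the whole organism (strain BALB/c) for pharmacokinetics, with Mus musculus as the target, read by LC-MS, at a dose of 5 mg/kg by the oral route (on this read-out higher numbers stand for higher oral bioavailability and lower numbers for lower oral bioavailability), and compound 2 `CN(C)S(=O)(=O)c1ccc(F)c(C#Cc2cc(Cl)ccc2OCC(=O)O)c1` stands highest at 58% of the oral dose reaching the circulation. Compound 3 `COCCNS(=O)(=O)c1ccc(C)c(C#Cc2cc(Cl)ccc2OCC(=O)O)c1` gives 33% in the same test, clearly lower. Compound 1 `O=C(O)COc1ccc(Cl)cc1C#Cc1ccc(CO)cc1F` lies lower still at 3% and is the furthest from compound 2.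

Compound 4 `CS(=O)(=O)c1ccc(F)c(C#Cc2cc(Cl)ccc2OCC(=O)O)c1` has not yet been measured. It differs from compound 2 in one place, with methyl in place of dimethylamino on a sulfonyl sulfur.

Among the measured compounds shown here, no measured pair isolates this change, so the evidence is indirect. Compound 3 carries a different group on its sulfonyl sulfur and differs elsewhere too, yet it still reaches 33% in this assay as a guide. A modest fall just beyond the usual scatter is therefore expected, estimated as a number 13 percentage points lower from compound 2 to compound 4 (beyond the scatter) for this change. For compound 4 the estimated value is 45% with an expected range from 20% to 75% in this measure.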

Compound 4, oral bioavailability: 24%
Compound 4: middle estimate off by 21 percentage points, on the high side; low and high end bracket the measured number.
By their numbers in this assay, from the lowest: compound 1; then compounds 4 and 3 (each within the scatter of the next); then compound 2.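

Among the compounds shown here, this pair is the first in the set to differ in one place only, so the change can now be read directly rather than inferred from compounds that differ elsewhere too. In this assay, methyl in place of dimethylamino on a sulfonyl sulfur gives a number 34 percentage points lower from compound 2 to compound 4 (beyond the scatter) and the step is large, which shows that oral bioavailability in this series depends strongly on the group at this sulfonyl sulfur. Nothing measured here explains why the step is this large.

As far as these compounds go, with only dimethylamino and methyl compared on an otherwise unchanged core, it remains open where a plain amino group, an ethyl group or a morpholine ring on the same sulfur would fall. From the compounds shown here alone, it also remains open whether the same swap would give a similar step on a core carrying methyl instead of fluorine.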